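The compounds below may be only part of what the source reports. "The series", "measured", "known", "first", "only" and "open" are said of these compounds alone.

In a functional assay on the whole organism with Mus musculus as the target (on this read-out higher numbers stand for an effect only at larger amounts of compound and lower numbers for an effect already at smaller amounts), compound 1 `O=C1CCC(O)(c2cccc(C(F)(F)F)c2)N1` reports only a limit, > 200 mg/kg. Compound 2 `CN1C(=O)CCC1(O)c1cccc(C(F)(F)F)c1` gives a number, 93.8 mg/kg. The change between them is an at least 2.1-fold lower number from compound 1 to compound 2 (0.32 log units; beyond the scatter). Compound 3 `CCCN1C(=O)CCC1(O)c1cccc(C(F)(F)F)c1` again reports only a limit, > 200 mg/kg, so it has no number of its own. Compound 4 `CCCCN1C(=O)CCC1(O)c1cccc(C(F)(F)F)c1` extends its propyl to butyl: methyl in place of hydrogen on a saturated chain carbon, three bonds along the chain from an amide-type nitrogen in a ring. The closest guide is an at least 2.1-fold higher number from compound 2 to compound 3 (0.32 log units; beyond the scatter), which lengthened the same chain. The other route offers a step that the two limits leave unreadable from compound 1 to compound 3 and adds nothing. A small further rise in this assay is therefore expected, and a second limit is the likelier report. The expected change is a step that the limit leaves unreadable from compound 3 to compound 4. For compound 4 the estimated value is 260 mg/kg, with an expected range of 120 mg/kg to 550 mg/kg.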

Compound 4, dose for half-maximal effect: > 200 mg/kg
Compound 4 gave a limit, no number; the forecaster's own chance of this, stated with the estimate: 70%; the middle value does not contradict the limit.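

In this assay, butyl on the amide-type nitrogen gives an at least 2.1-fold higher number from compound 2 to compound 4 (0.32 log units; beyond the scatter), so a second chain longer than methyl now sits on the far side of compound 2. Among the compounds shown, only the methyl of compound 2 gives a number. The steps from compound 3 to compound 4 and from compound 1 to compound 4 cannot be read, so any difference among these three compounds stays hidden: the limit of > 200 mg/kg in this assay, at which 3 of the 4 values shown sit.

Going by these compounds, whether propyl and butyl differ at all remains open. So does whether an ethyl or a cyclopropyl on that nitrogen would give a number in this assay.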